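From 3-Chlorophenyl to Pyridin-4-yl: Expected Maximal Response

The source may report more compounds than this note shows. Statements on the series, on what has been measured and on what is new or still open speak of the compounds shown alone.

Compound 1 `CCOC(=O)c1c(C)[nH]c(=O)c(C#N)c1-c1ccco1`: 93%
Compound 2 `CCOC(=O)c1c(C)[nH]c(=O)c(C#N)c1-c1cccc(Cl)c1`: 99%

Among the compounds with values here, in a functional assay on aorta (Rattus norvegicus) for inhibition (a lower number here means a smaller maximal response, a higher number a larger maximal response), compound 2 gives 99%, the higher of the two numbers measured so far, and compound 1 gives 93%, a number within the usual scatter of compound 2. Within the data shown here, the only measured step, a number 6 percentage points higher from compound 1 to compound 2 (within the scatter), swapped one aromatic ring for another at this position and stayed within the scatter. Compound 3 `CCOC(=O)c1c(C)[nH]c(=O)c(C#N)c1-c1ccncc1` differs from compound 2 by pyridin-4-yl in place of 3-chlorophenyl on an aromatic carbon. Since that one step, a number 6 percentage points higher from compound 1 to compound 2 (within the scatter), bears on the same position and stayed within the scatter, no change beyond the scatter is expected: a number 5 percentage points lower from compound 2 to compound 3 (within the scatter). Compound 3 is therefore expected to give 94%, between 78% and 100%.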

Compound 3, largest response reached (reported as efficacy), in percent of the reference or control that the assay uses: 86.4%
Estimate against measurement, compound 3: 7.6 percentage points above; low and high end bracket the measured number.
By their numbers in this assay, from the lowest: compounds 3, 1 and 2 (each within the scatter of the next, the first and the last beyond it).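

In this assay this position now gives its first step beyond the scatter, a number 12.6 percentage points lower from compound 2 to compound 3 (beyond the scatter), as pyridin-4-yl, with its hydrogen-bond acceptor, replaces 3-chlorophenyl. Against furan-2-yl the same ring gives a number 6.6 percentage points lower from compound 1 to compound 3 (within the scatter), so the choice of aromatic ring here can shift the maximal response, though only the pair with 3-chlorophenyl shows it. Nothing measured here explains this difference.

All three compounds carry an aromatic ring at this position. Going by these compounds, how an amine, a carboxylic acid or a longer chain in its place would behave remains open.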